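Swapping a cyclohexylmethyl for a 2-methylphenyl on a shared core

The compounds below may be only part of what the source reports. "The series", "measured", "known", "first", "only" and "open" are said of these compounds alone.

The three compounds with results so far share one fused core and differ in the groups hung on its nitrogen atoms. Compound 1, `Cc1nc2c(cnn2-c2ccccc2)c(=O)n1-c1cccc(Cl)c1`, stands in an in vitro functional assay on cells for antagonist activity at metabotropic glutamate receptor 5 (Homo sapiens), read by FLIPR and calcium flux (a lower number here means a stronger inhibitor, a higher number a weaker inhibitor), as "not determined" (no result reported). Compound 2, `Cc1nc2c(cnn2-c2ccccc2)c(=O)n1-c1ccc(OC(F)(F)F)cc1`, reaches only the limit of this assay at > 100000 nM. Compound 3, `Cc1nc2c(cnn2CC2CCCCC2)c(=O)n1-c1ccc(Cl)cc1`, likewise gives only a limit in this assay, > 100000 nM. So compound 3 has no single number of its own to stand on; it sits where (the limit of > 100000 nM in this assay, at which 2 of the 3 values shown sit), and with it compound 2 offers no measured step for comparison.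

The next compound, compound 4, `Cc1ccccc1-n1ncc2c(=O)n(-c3ccc(Cl)cc3)c(C)nc21`, differs from compound 3 in one place: 2-methylphenyl in place of cyclohexylmethyl on an aromatic nitrogen. Among the measured compounds shown here, no measured pair in this set shows what such a swap does, and compound 1, the only other compound without the cyclohexylmethyl, carries no value. With two limits and one blank, there is no direction to lean on, and the expectation is that compound 4 stays near the limit as well. The step from compound 3 to compound 4 is expected to be an at least 1.2-fold lower number from compound 3 to compound 4 (0.09 log units; that floor lies within the scatter). Compound 4 is therefore estimated at 80000 nM in this assay, within a range from 10000 nM to 200000 nM.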

Compound 4, half-maximal inhibitory concentration: 9500 nM
Compound 4: middle estimate off by 8.4-fold (0.93 log units), on the high side, and the stated range ends above it.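

Among the compounds shown here, putting 2-methylphenyl in place of cyclohexylmethyl on this aromatic nitrogen gives an at least 10-fold lower number from compound 3 to compound 4 (1.02 log units; beyond the scatter) in this assay, the first measured step in this set, and a large one. The two groups match in everything counted for them, with 7 heavy atoms each, all carbon, no hydrogen-bond donors or acceptors and no net charge, so the step goes with a six-membered non-aromatic ring giving way to a six-membered aromatic ring that bears a methyl group. Compound 4 also provides the first single number in the set, a point from which further changes can be measured, while the other compounds with a result remain at a limit: the limit of > 100000 nM in this assay, at which 2 of the 4 values shown sit.

This one pair cannot separate the contribution of the aromatic ring from that of its methyl group, and it shows the swap only with the chlorophenyl group on the other nitrogen of the shared core. On these data alone, how a pyridine ring, a methoxy-bearing phenyl ring or a chain ending in an amine would fare on this aromatic nitrogen remains open.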